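A few compounds are considered here, and "the series" means these few. Any claim that something is new, unique, unknown or untested is made for them only; others in the source may bear on it.

Compound 3, with the structure `CCN(CC)CCCCCCOc1ccc(/C=C/C(=O)O)cc1OC`, stands lowest of the three measured compounds in a physicochemical assay for lipophilicity, using the shake flask method, measured as octanol-water partition, at pH 7.4; a higher number here means a more lipophilic compound, a lower number a more polar compound: compound 3 gives 1.29. Its nearest neighbours are compound 1, with the structure `COc1cc(/C=C/C(=O)Nc2ccccc2)ccc1OCCCCCCCCCCN(C)C`, which in this assay gives 1.8, and compound 2, with the structure `CCOC(=O)/C=C/c1ccc(OCCCCCCN(CC)CC)c(OC)c1`, which gives 1.8; both sit beyond the scatter above compound 3. For the measured compounds named here, the one step measured between close relatives is a number 0.51 log units lower from compound 2 to compound 3 (beyond the scatter), and it concerns the acid end of the molecule, not the chain.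

Compound 4, with the structure `CCN(CC)CCCCCCCCOc1ccc(/C=C/C(=O)O)cc1OC`, differs from compound 3 by 2-(diethylamino)ethyl in place of diethylamino on a saturated chain carbon, six bonds along the chain from an oxygen on an aromatic ring. No measured step of this kind exists among these compounds; compound 1 carries a longer chain than compound 3 and gives a higher partition coefficient, but it also differs at the amine and at the amide, so its value shows only that longer-chain relatives reached higher numbers. Compound 4 is therefore expected to rise modestly, by a number 0.61 log units higher from compound 3 to compound 4 (beyond the scatter), and its estimated value is 1.9, within a range from 1.3 to 2.5.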

Compound 4, partition coefficient: 1.51
For compound 4 the middle estimate is 0.39 log units above the measured one; measured number inside the range.
By their numbers in this assay, from the lowest: compounds 3, 4, 1 and 2 (each within the scatter of the next, the first and the last beyond it).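

In this assay the chain itself now has a measured step, a number 0.22 log units higher from compound 3 to compound 4 (within the scatter), so 2-(diethylamino)ethyl in place of diethylamino at this position leaves two values that this read-out cannot tell apart. For the compounds shown here, the earlier compounds could not show this: their one step between close relatives concerned the acid end, and compound 1 differs from compound 3 in more than one place. No measured evidence bears on this result.

Going by these compounds, whether a longer chain, such as 4-(diethylamino)butyl in place of diethylamino, would carry the number beyond the scatter stays open. So does whether the same chain difference would read alike with an ethyl ester or an anilide in place of the carboxylic acid, or with a dimethylamino group at the chain end.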